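The source may hold more compounds than are shown below. What is called first, only, known or untested is meant among the compounds shown, and "the series" means these compounds.

Two compounds share one core. Compound 1 `Fc1ccc(Cc2ccc3c(NCCCNCc4ccco4)ccnc3c2)cc1` was tested in an ADME assay on HepG2 cells (Homo sapiens) for cytotoxicity, read by luminescence, CellTiter-Glo and ATP content, with a stated time of 72 h (a lower number here means that less compound is needed, a higher number that more compound is needed for the effect), and compound 1 gave 5600 nM. Compound 2 `Fc1ccc(Cc2ccc3c(NCCCNCc4ccco4)ccnc3c2)c(Cl)c1` carries chloro in place of hydrogen on an aromatic carbon, and in this assay compound 2 gave 5730 nM, so the change produced a 1.0-fold higher number from compound 1 to compound 2 (0.01 log units; within the scatter).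

Compound 3 `COc1ccc(F)cc1CNCCCNc1ccnc2cc(Oc3ccccc3)ccc12` rests on a different core; the difference between the two cores is not broken down here. In this assay compound 3 gave 1500 nM, the lowest of the three numbers and beyond the scatter from both others.

Compound 4 `COc1ccc(F)cc1CNCCCNc1ccnc2cc(Oc3ccc(Cl)cc3)ccc12` differs from compound 3 by chloro in place of hydrogen on an aromatic carbon. This is the same kind of change as that from compound 1 to compound 2, not the same: there the chloro entered ortho to a large group and meta to a fluoro group, here it enters para to a large group. For the measured compounds named here, the only comparable step observed was flat, so the estimated step is a 1.1-fold higher number from compound 3 to compound 4 (0.03 log units; within the scatter), because a 1.0-fold higher number from compound 1 to compound 2 (0.01 log units; within the scatter) lay within the scatter. Compound 4 is accordingly expected to give 1600 nM, with a likely range from 800 nM to 3400 nM.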

Compound 4, half-maximal effective concentration: 4500 nM
Beside the measured number, compound 4's estimate is 2.8-fold (0.45 log units) below it; measured number outside the range, above it.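

In this assay, chloro in place of hydrogen gave a 3.0-fold higher number from compound 3 to compound 4 (0.48 log units; beyond the scatter), so this step was not flat as the earlier one had been. Set side by side, the two steps show that the size of this change did not carry from one core to the other: the same change on two cores in this assay, a 1.0-fold higher number (0.01 log units; within the scatter) from compound 1 to compound 2 and a 3.0-fold higher number (0.48 log units; beyond the scatter) from compound 3 to compound 4, 2.9-fold (0.47 log units) apart, beyond the scatter of two such steps. For the compounds shown here, this shows that, for these two pairs, the step on the core of compound 1 did not predict the step on the core of compound 3, but it does not show what sets them apart, as the chloro differs in its place on the ring as well as in its core, and each core offers only one pair.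

The compounds shown leave open whether a bromo or trifluoromethyl group entering in place of the chloro would give a step like that from phenoxy to 4-chlorophenoxy. They also leave open whether that step would persist with a longer chain between the two amine nitrogens.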